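The source may hold more compounds than are shown below. What is called first, only, known or untested is meant among the compounds shown, and "the series" means these compounds.

Measured in an ADME assay (liver) for pharmacokinetics, with Liver microsome (Homo sapiens) as the target, using microsomes; on this read-out lower numbers stand for a shorter-lived compound and higher numbers for a longer-lived compound:
Compound 1 `CCOc1cc(NC(=O)C2(NC(=O)c3ccc4c(C5CCCC5)c(-c5ncc(Cl)cn5)n(C)c4c3)CCC2)ccc1/C=C/C(=O)OCOP(=O)(O)OC(C)(C)C` gives 1.48 h.
Compound 2 `CCOc1cc(NC(=O)C2(NC(=O)c3ccc4c(C5CCCC5)c(-c5ncc(Cl)cn5)n(C)c4c3)CCC2)ccc1/C=C/C(=O)OCC(C)C` gives only a limit of the assay, > 5 h.
Compound 3 `CCOc1cc(NC(=O)C2(NC(=O)c3ccc4c(C5CCCC5)c(-c5ncc(Cl)cn5)n(C)c4c3)CCC2)ccc1/C=C/C(=O)OCCOCCOC` gives 0.85 h.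

Compound 2 carries the isobutyl ester and stands at the upper edge of what this set shows: its result in this assay is a limit rather than a number, and the limit of > 5 h in this assay, at which 1 of the 3 values shown sits, marks that edge. The step from it to the next compound replaces that group: (pyrrolidin-1-yl)carbonyl in place of isopropyl on a saturated chain carbon bound to an oxygen next to a carbonyl group. Compound 4 `CCOc1cc(NC(=O)C2(NC(=O)c3ccc4c(C5CCCC5)c(-c5ncc(Cl)cn5)n(C)c4c3)CCC2)ccc1/C=C/C(=O)OCC(=O)N1CCCC1` is thus the ester bearing ((pyrrolidin-1-yl)carbonyl)methoxy in place of isobutoxy. Going by the values given here, two measured steps bear on this change, both touching the same isopropyl-bearing compound. an at least 5.8-fold lower number from compound 2 to compound 3 (0.76 log units; beyond the scatter) puts (2-methoxyethoxy)methyl in place of isopropyl. In the listed direction, an at least 3.3-fold higher number from compound 1 to compound 2 (0.52 log units; beyond the scatter) shows the phosphorus-bearing group giving a much shorter-lived compound than the isopropyl one. Both departures from isopropyl at this position shorten the half-life well beyond the scatter. Compound 4 likewise departs from isopropyl, so a step of an at least 3.3-fold lower number from compound 2 to compound 4 (0.52 log units; beyond the scatter) is expected. Compound 4 is therefore estimated to give about 1.5 h in this assay, within a range of 0.6 h to 4 h.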

Compound 4, half-life: 1.65 h
For compound 4 the middle estimate is 1.1-fold (0.04 log units) below the measured one; low and high end bracket the measured number.
By their numbers in this assay, from the lowest: compounds 3, 1 and 4 (each within the scatter of the next). At a limit, above all of these: compound 2.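

Replacing isopropyl with (pyrrolidin-1-yl)carbonyl on a saturated chain carbon bound to an oxygen next to a carbonyl group adds a third departure from the isobutyl ester that lies beyond the scatter in this assay: an at least 3.0-fold lower number from compound 2 to compound 4 (0.48 log units; beyond the scatter). This time the entering group carries a five-membered non-aromatic ring, yet it cannot be told apart from the other two replacements, with a 1.9-fold higher number from compound 3 to compound 4 (0.29 log units; within the scatter) and a 1.1-fold higher number from compound 1 to compound 4 (0.05 log units; within the scatter), so among compounds 1, 3 and 4 the differing groups at this position give no separation. Compound 2 thus remains alone at the upper edge of the set, and its result is a limit and not a number, which leaves the full size of its steps unknown: the limit of > 5 h in this assay, at which 1 of the 4 values shown sits.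

From the compounds shown here alone, it remains open whether a longer straight chain such as n-hexyl, or a carbocycle such as cyclohexyl, at this place would stay with compound 2 or fall in with compounds 1, 3 and 4. Going by these compounds, it is equally open whether an open-chain dimethylaminocarbonyl group in place of (pyrrolidin-1-yl)carbonyl would read like compound 4.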